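A few compounds are considered here, and "the series" means these few. Any claim that something is new, unique, unknown or untested is made for them only; others in the source may bear on it.

Among the measured compounds shown here, in an ADME assay on Vero cells (Chlorocebus sabaeus) for cytotoxicity, read by MTT assay (a lower number here means a stronger inhibitor, a higher number a weaker inhibitor), compound 2 `C=CCOc1cc(OC)c(C(=O)/C=C/c2ccco2)c(OCC=C)c1` gives 191000 nM, the higher of the two numbers so far, while compound 1 `C=CCOc1cc(OC)c(C(=O)/C=C/c2ccccc2Br)c(OCC=C)c1` gives 13900 nM. Compound 3 `C=CCOc1cc(OC)c(C(=O)/C=C/c2ccc(Cl)cc2)c(OCC=C)c1` carries 4-chlorophenyl in place of furan-2-yl on a double-bonded chain carbon bound to a double-bonded chain carbon. For the measured compounds named here, the only measured step bearing on this, furan-2-yl in place of 2-bromophenyl, is the large 14-fold higher number from compound 1 to compound 2 (1.14 log units; beyond the scatter). Leaving furan-2-yl for a halogen-bearing phenyl again should therefore run the opposite way, though one pair is thin support. The expected change is an 8.7-fold lower number from compound 2 to compound 3 (0.94 log units; beyond the scatter), a large step to a lower number. The estimated value for compound 3 is 22000 nM, within a range of 8000 nM to 60000 nM.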

Compound 3, half-maximal inhibitory concentration: 10400 nM
Compound 3: the middle estimate sits 2.1-fold (0.33 log units) above what was measured; the range from low to high includes it.
By their numbers in this assay, from the lowest: compounds 3 and 1 (each within the scatter of the next); then compound 2.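

In this assay, leaving furan-2-yl for a second halogen-bearing phenyl group gives an 18-fold lower number from compound 2 to compound 3 (1.26 log units; beyond the scatter) and so the large gap at this position is not confined to 2-bromophenyl. Exchanging the halogen-bearing phenyl groups themselves gives a 1.3-fold lower number from compound 1 to compound 3 (0.13 log units; within the scatter) and so 2-bromophenyl and 4-chlorophenyl cannot be told apart here. Going by these compounds, whether a phenyl group carrying an amine or a carboxylic acid would stay with these two or move toward furan-2-yl remains open. No evidence at hand accounts for the gap between furan-2-yl and the halogen-bearing phenyl groups.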